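The source may report more compounds than this note shows. Statements on the series, on what has been measured and on what is new or still open speak of the compounds shown alone.

Compound 1 `COc1ccc(C2N=C(SCc3ccccc3)NC(C)=C2C(=O)Nc2ccc(Br)cc2)cc1`: 7.2%
Compound 2 `COc1ccc(C2N=C(SCc3ccccc3Cl)NC(C)=C2C(=O)Nc2ccc(Br)cc2)cc1`: 10.8%

In a functional assay on the whole organism (artery, strain albino) with Rattus norvegicus as the target, with a stated time of 720 min, at a dose of 10 mg/kg by the oral route (a lower number here means less inhibition, a higher number more inhibition at the dose given (going by the name of the read-out)), the number of compound 2 is the higher of the two, but the step of a number 3.6 percentage points higher from compound 1 to compound 2 (within the scatter) lies within the scatter, so the two compounds cannot be told apart on these data. Compound 3 `COc1ccc(C2N=C(SCc3cccc(Cl)c3)NC(C)=C2C(=O)Nc2ccc(Br)cc2)cc1` has not been measured; it differs from compound 2 by 3-chlorophenyl in place of 2-chlorophenyl on a saturated chain carbon bound to a sulfur. Going by the values given here, no measured step moves a chloro group from one place to another on this ring; the only step in hand, a number 3.6 percentage points higher from compound 1 to compound 2 (within the scatter), was within the scatter. A step of a number 0.8 percentage points lower from compound 2 to compound 3 (within the scatter) of no size beyond the scatter is therefore expected. Compound 3 is estimated at 10%, between 2% and 20%.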

Compound 3, a percentage reported as inhibition, in the whole organism at one dose (the size of the read-out at that dose, not a potency): 26.8%
Estimate against measurement, compound 3: 16.8 percentage points below, and the stated range ends below it.
By their numbers in this assay, from the lowest: compounds 1 and 2 (each within the scatter of the next); then compound 3.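

In this assay, 3-chlorophenyl in place of 2-chlorophenyl on a saturated chain carbon bound to a sulfur gives a number 16 percentage points higher from compound 2 to compound 3 (beyond the scatter) with no change in atom count. Chloro in place of hydrogen also gives a number 19.6 percentage points higher from compound 1 to compound 3 (beyond the scatter) here, whereas the earlier chloro step stayed within the scatter, so on this ring the outcome depends on where the chloro group stands. Nothing measured here explains this difference. Still open, on these data alone, is whether bromo, methyl or methoxy in place of this chloro would give a similar reading, and how the single-dose reading relates to potency.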